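The source may hold more compounds than are shown below. What is called first, only, known or untested is meant among the compounds shown, and "the series" means these compounds.

Working notes on the series. Compound 1 `c1ccc(-c2ccc3c(NCCCNCc4ccco4)ccnc3c2)cc1` is the anchor; in a physicochemical assay for solubility, with a stated time of 18 h, at pH 7.4 (on this read-out lower numbers stand for lower solubility and higher numbers for higher solubility), compound 1 gives 32000 nM. Compound 2 `COc1ccc(F)cc1CNCCCNc1ccnc2cc(-c3ccccc3)ccc12` gives 32000 nM in this assay, and the step of no change at the digits printed from compound 1 to compound 2 (within the scatter) shows that compound 1 stands level with compound 2, with nothing between them beyond the scatter. Compound 3 `CC(C)(C)c1ccc(-c2ccc3c(NCCCNCc4ccco4)ccnc3c2)cc1` differs from compound 1 by tert-butyl in place of hydrogen on an aromatic carbon. Going by the values given here, no measured step covers this change; the only step known, from compound 1 to compound 2, sits on a different part of the molecule. A modest downward step a 2.7-fold lower number from compound 1 to compound 3 (0.43 log units; beyond the scatter) in this assay is expected, though it may fall within the scatter. For compound 3 the estimate in this assay is 12000 nM, between 3000 nM and 32000 nM.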

Compound 3, solubility: 32000 nM
Beside the measured number, compound 3's estimate is 2.7-fold (0.43 log units) below it; measured number inside the range.
By their numbers in this assay, from the lowest: compounds 1, 2 and 3 (each within the scatter of the next).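

In this assay the change from phenyl to 4-(tert-butyl)phenyl gives no change at the digits printed from compound 1 to compound 3 (within the scatter) and so adds a second place on the molecule where the read-out holds level, since the earlier step touched only the group on the saturated chain carbon. At this position, a group of 4 heavy atoms with no ring leaves the number within the scatter. Nothing available here accounts for this result.

On these data alone, whether an amine or a carboxylic acid at this position would shift the number remains open. So does whether tert-butyl would behave the same way on compound 2.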